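Swapping Trifluoromethyl for Fluoro on Compound 3

The source may report more compounds than this note shows. Statements on the series, on what has been measured and on what is new or still open speak of the compounds shown alone.

Measured compounds and their values in a functional assay on BT-474 cells (Homo sapiens) for cytotoxicity, read by MTT assay, with a stated time of 48 h; a higher number here means a weaker inhibitor, a lower number a stronger inhibitor:
compound 1 `O=C(/C=C\Nc1ccc(F)cc1)c1nc(-c2ccc(F)cc2)n2ccccc12` gives 16900 nM
compound 2 `COc1ccc(N/C=C\C(=O)c2nc(-c3ccc(F)cc3)n3ccccc23)cc1` gives 15700 nM
compound 3 `O=C(/C=C\Nc1ccc(Cl)cc1)c1nc(-c2ccc(C(F)(F)F)cc2)n2ccccc12` gives 3820 nM

Compound 3 has the lowest number of the three; compound 2 lies nearest, compound 1 furthest, both beyond the scatter. Compound 4 `O=C(/C=C\Nc1ccc(Cl)cc1)c1nc(-c2ccc(F)cc2)n2ccccc12` differs from compound 3 by fluoro in place of trifluoromethyl on an aromatic carbon. Among the measured compounds shown here, the single measured step, a 1.1-fold lower number from compound 1 to compound 2 (0.03 log units; within the scatter), concerns a different position and was within the scatter, so it says nothing about this swap. Compound 1 and compound 2, which both carry the fluoro group, sit well above compound 3. The expected step is therefore a 2.6-fold higher number from compound 3 to compound 4 (0.42 log units; beyond the scatter), toward a higher number. Compound 4 is estimated at 10000 nM, within 4000 nM to 25000 nM.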

Compound 4, half-maximal inhibitory concentration: 7030 nM
Estimate against measurement, compound 4: 1.4-fold (0.15 log units) above; the range from low to high includes it.
By their numbers in this assay, from the lowest: compounds 3 and 4 (each within the scatter of the next); then compounds 2 and 1 (each within the scatter of the next).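

In this assay, changing 4-(trifluoromethyl)phenyl to 4-fluorophenyl with the chloro group held constant gives a 1.8-fold higher number from compound 3 to compound 4 (0.26 log units; within the scatter), so this position shows no clear preference between these two groups. With 4-fluorophenyl held constant, the changes at the other position, chloro in place of methoxy and chloro in place of fluoro, give a 2.2-fold lower number from compound 2 to compound 4 (0.35 log units; beyond the scatter) and a 2.4-fold lower number from compound 1 to compound 4 (0.38 log units; beyond the scatter). No supporting evidence explains any of these steps. Going by these compounds, only trifluoromethyl and fluoro are compared at this position, so the effect of an amine or a carboxylic acid there remains open.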